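Replacing the Amide Substituent in Compound 3

A few compounds are considered here, and "the series" means these few. Any claim that something is new, unique, unknown or untested is made for them only; others in the source may bear on it.

Measured compounds:
compound 1 `CCOC(=O)c1sc(-c2nc3ccccc3n2CC)nc1C`: 9850 nM
compound 2 `CCOC(=O)Cc1csc(-c2nc3ccccc3n2C)n1`: > 20000 nM
compound 3 `Cc1nc(-c2nc3ccccc3n2Cc2ccccc2)sc1C(=O)NC(C)C`: 6900 nM

All three were tested in a functional assay on SMMC-7721 cells (Homo sapiens) for cytotoxicity, read by MTT assay, with a stated time of 24 h; on this read-out lower numbers stand for stronger inhibition and higher numbers for weaker inhibition. Compound 3 gives 6900 nM, and compound 1 gives 9850 nM; these two numbers lie within the usual scatter of each other, so neither can be called stronger. For compound 2 the result is only a limit of the assay, (the limit of > 20000 nM in this assay, at which 1 of the 3 values shown sits), not a number.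

Compound 4 `Cc1nc(-c2nc3ccccc3n2Cc2ccccc2)sc1C(=O)N1CCCCC1` is the next analogue. It differs from compound 3 in one place: piperidin-1-yl in place of isopropylamino on a carbonyl carbon. The hydrogen-bond donor of compound 3 is thereby removed and a saturated ring is introduced. Among the compounds with values here, no measured pair in this set shows what such a change does here, so the expectation rests only on the values of compound 3 and compound 1, which sit close together.

Compound 4 is expected to give about 9000 nM, with a range from 3500 nM to 20000 nM. The expected step of a 1.3-fold higher number from compound 3 to compound 4 (0.12 log units; within the scatter) is small, toward a somewhat weaker result, and is not expected to exceed the scatter clearly.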

Compound 4, half-maximal inhibitory concentration: > 20000 nM
Compound 4 gave a limit, no number; the forecaster's own chance of this, stated with the estimate: 20%; middle value at least 2.2-fold (0.34 log units) from the limit.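

The earlier compounds shown here contained no pair differing in one place, so they could not show whether the group on this carbonyl carbon matters. Putting piperidin-1-yl in place of isopropylamino gives an at least 2.8-fold higher number from compound 3 to compound 4 (0.46 log units; beyond the scatter) and so shows that, in this assay, the result does depend on this group, and that this change goes toward weaker inhibition. As far as these compounds go, compound 4 gives only a limit of the assay, not a number, so the true size of the step stays unknown: the limit of > 20000 nM in this assay, at which 2 of the 4 values shown sit.

The change removes a hydrogen-bond donor, introduces a ring and adds heavy atoms all at once, and this one pair cannot separate these differences. Cyclohexylamino, which keeps the donor and carries a ring, and dimethylamino, which has neither, would each pull these differences apart at this carbonyl carbon.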